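Estimating compound 3 from two measured neighbours

A few compounds are considered here, and "the series" means these few. Any claim that something is new, unique, unknown or untested is made for them only; others in the source may bear on it.

Measured in a toxicity assay on L02 cells (Homo sapiens) for cytotoxicity, read by MTT assay, with a stated time of 72 h; a lower number here means a stronger inhibitor, a higher number a weaker inhibitor:
- Compound 1 `O=C1c2c[n+]([O-])c3ccccc3c2C(=O)c2c1c1ccccc1n2CCN1CCCC1`: 930 nM
- Compound 2 `CCCN1CCN(CCCCn2c3c(c4ccccc42)C(=O)c2c[n+]([O-])c4ccccc4c2C3=O)CC1`: 6830 nM

Compound 2 holds the higher of these two numbers, which makes it the weaker inhibitor of the pair. The next compound, compound 3 `CN1CCN(CCCn2c3c(c4ccccc42)C(=O)c2c[n+]([O-])c4ccccc4c2C3=O)CC1`, is still unmeasured. Its change from compound 2 is 4-methylpiperazin-1-yl in place of (4-propylpiperazin-1-yl)methyl on a saturated chain carbon, three bonds along the chain from an aromatic nitrogen. Here 4-methylpiperazin-1-yl stands in place of (4-propylpiperazin-1-yl)methyl on a saturated chain carbon, three bonds along the chain from an aromatic nitrogen.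

Among the compounds with values here, only one measured step bears on this: a 7.3-fold higher number from compound 1 to compound 2 (0.87 log units; beyond the scatter). That step was modest and involved a different exchange, so it offers limited guidance. A modest move is expected again, this time to a lower number, and smaller than that step. The expected change in this assay is a 2.5-fold lower number from compound 2 to compound 3 (0.40 log units; beyond the scatter). Compound 3 is estimated at 2700 nM, with an expected range of 800 nM to 8000 nM.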

Compound 3, half-maximal inhibitory concentration: 230 nM
Compound 3: middle estimate off by 12-fold (1.07 log units), on the high side; measured number outside the range, below it.
By their numbers in this assay, from the lowest: compound 3; then compound 1; then compound 2.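

In this assay, the group at the end of this chain matters more than the first pair could show: 4-methylpiperazin-1-yl in place of (4-propylpiperazin-1-yl)methyl gives a 30-fold lower number from compound 2 to compound 3 (1.47 log units; beyond the scatter), a large step, although both groups carry the same kind of six-membered ring and differ by only a few heavy atoms. Set against the pyrrolidin-1-yl chain end, (4-methylpiperazin-1-yl)methyl gives a 4.0-fold lower number from compound 1 to compound 3 (0.61 log units; beyond the scatter), so a piperazine ring on the chain does not in itself go with a higher number. Nothing measured here accounts for the size of either step.

As far as these compounds go, the large step changes the chain length and swaps propyl for methyl together, so the share of each remains open. A 4-ethylpiperazin-1-yl group or a morpholine ring on the same chain would help to separate the effects of the end group.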